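A few compounds are considered here, and "the series" means these few. Any claim that something is new, unique, unknown or untested is made for them only; others in the source may bear on it.

In a functional assay on MCF7 cells (Homo sapiens) for inhibition, read by MTT assay (a higher number here means a weaker inhibitor of growth, a lower number a stronger inhibitor of growth), compound 1 `COc1cc2oc(-c3cccc(NC(=O)c4ccccc4)c3)cc(=O)c2c(OC)c1OC` gives 12100 nM, compound 2 `COc1cc2oc(-c3cccc(NC(=O)c4cccc(Br)c4)c3)cc(=O)c2c(OC)c1OC` gives 6340 nM and compound 3 `COc1cc2oc(-c3cccc(NC(=O)c4ccc(C#N)cc4)c3)cc(=O)c2c(OC)c1OC` gives 12700 nM. Compound 3 therefore stands within the scatter of both other compounds. Compound 4 `COc1cc2oc(-c3cccc(NC(=O)c4cccc(C#N)c4)c3)cc(=O)c2c(OC)c1OC` differs from it as follows: 3-cyanophenyl in place of 4-cyanophenyl on a carbonyl carbon. Going by the values given here, three measured steps bear on this change: a 1.9-fold lower number from compound 1 to compound 2 (0.28 log units; within the scatter), a 1.0-fold higher number from compound 1 to compound 3 (0.02 log units; within the scatter) and a 2.0-fold higher number from compound 2 to compound 3 (0.30 log units; within the scatter). All three lie within the scatter, so no step beyond the scatter is expected in this assay. The estimated step is a 1.3-fold lower number from compound 3 to compound 4 (0.10 log units; within the scatter). Compound 4 is expected at 10000 nM, with an estimated range of 5000 nM to 20000 nM.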

Compound 4, concentration for 50% growth inhibition: 41700 nM
Beside the measured number, compound 4's estimate is 4.2-fold (0.62 log units) below it; measured number outside the range, above it.
By their numbers in this assay, from the lowest: compounds 2, 1 and 3 (each within the scatter of the next); then compound 4.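

In this assay the place of the nitrile now counts: a 3.3-fold higher number from compound 3 to compound 4 (0.52 log units; beyond the scatter) for 3-cyanophenyl in place of 4-cyanophenyl on a carbonyl carbon is a step beyond the scatter, unlike any earlier step. With a 3.4-fold higher number from compound 1 to compound 4 (0.54 log units; beyond the scatter) and a 6.6-fold higher number from compound 2 to compound 4 (0.82 log units; beyond the scatter) the 3-cyanophenyl group also stands apart from the unsubstituted phenyl and from 3-bromophenyl, so bromo and cyano do not read alike at this place. Going by these compounds, whether an amine or a carboxylic acid in place of the nitrile of compound 4 would track bromo or cyano stays open. Nothing available gives a reason for these steps.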